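This account rests on a few compounds, and the source may have more. Where it says the series, first, only, none or still open, it means among the compounds named here.

In a functional assay on MCF7 cells (Homo sapiens) for cytotoxicity, read by MTT assay and propidium iodide staining, with a stated time of 24 h (on this read-out lower numbers stand for stronger inhibition and higher numbers for weaker inhibition), compound 1 (`Cc1ccc(-c2nnc(SCC(=O)c3ccccc3)o2)c(O)c1`) gives 150 nM and compound 2 (`COc1ccc(-c2nnc(SCC(=O)c3ccccc3)o2)c(O)c1`) gives 280 nM. Compound 3 (`CN(C)c1ccc(-c2nnc(SCC(=O)c3ccc(Br)cc3)o2)cc1`) gives 550 nM, so compound 2 stands within the scatter of both neighbours. Compound 4 (`COc1ccc(-c2nnc(SCC(=O)c3ccc(Br)cc3)o2)c(O)c1`) differs from compound 2 by bromo in place of hydrogen on an aromatic carbon, which is phenyl to 4-bromophenyl. Among the compounds with values here, the only measured step, a 1.9-fold higher number from compound 1 to compound 2 (0.27 log units; within the scatter), is a different change, methoxy in place of methyl. Within the data shown here, compound 3 also carries the 4-bromophenyl group, but it differs from compound 2 elsewhere too, so no measured step isolates the bromo. No shift beyond the scatter is therefore expected, and the estimated step is a 1.1-fold lower number from compound 2 to compound 4 (0.03 log units; within the scatter). The value estimated for compound 4 is 260 nM, within an expected range of 100 nM to 650 nM.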

Compound 4, half-maximal inhibitory concentration: 260 nM
The estimate for compound 4 equals the measured number at the digits printed; low and high end bracket the measured number.
By their numbers in this assay, from the lowest: compounds 1, 4, 2 and 3 (each within the scatter of the next, the first and the last beyond it).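

In this assay, within the data shown here, the step from phenyl to 4-bromophenyl, a 1.1-fold lower number from compound 2 to compound 4 (0.03 log units; within the scatter), isolates this position for the first time and shows that bromo in place of hydrogen, para to a large group, leaves the number within the scatter. No supporting measurement bears on this result beyond the values themselves. The compounds shown leave open whether an amine or a carboxylic acid at this position would also stay within the scatter. They also leave open whether bromo would give a similar step on the core of compound 1.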